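Series notes: the amine substituent on the shared core

The compounds below may be only part of what the source reports. "The series", "measured", "known", "first", "only" and "open" are said of these compounds alone.

Of the compounds shown here, three of the shared core have been measured in a functional assay on the whole organism with Rattus norvegicus as the target; a lower number here means that less compound is needed, a higher number that more compound is needed for the effect. Compound 1 `Cc1ccn2c(C)c(C)nc2c1OCc1ccccc1` gives 16 mg/kg, compound 2 `CCCCc1nc2c(OCc3ccccc3)cccn2c1N` gives 7.5 mg/kg, and compound 3 `Cc1nc2c(OCc3ccccc3)cccn2c1NC=O` gives 10 mg/kg. Compound 3 sits second highest of the three numbers; its nearest neighbour is compound 2, and its furthest is compound 1, yet both gaps lie within the scatter, so no ordering among the three can be read from these values.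

Compound 4 `Cc1nc2c(OCc3ccccc3)cccn2c1N(C)C` is not yet measured in this assay. The change from compound 3 is dimethylamino in place of formylamino on an aromatic carbon. Among the compounds with values here, with no measured pair showing the same change, the expectation for compound 4 is a step of a 1.2-fold higher number from compound 3 to compound 4 (0.08 log units; within the scatter) in this assay, that is, nothing beyond the scatter. Compound 4 is therefore estimated at 12 mg/kg, with a range from 5 mg/kg to 30 mg/kg.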

Compound 4, dose for half-maximal effect: 2.8 mg/kg
Compound 4: middle estimate off by 4.3-fold (0.63 log units), on the high side, outside the stated range (below it).
By their numbers in this assay, from the lowest: compound 4; then compounds 2, 3 and 1 (each within the scatter of the next, the first and the last beyond it).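

In this assay, within the data shown here, dimethylamino in place of formylamino on this aromatic carbon gives a 3.6-fold lower number from compound 3 to compound 4 (0.55 log units; beyond the scatter) and is the first step beyond the scatter, so this position does respond to its substituent. The change removes the hydrogen-bond donor and keeps the heavy-atom count. No measurement on hand bears on the reason for the step.

Open, from the compounds shown here alone, is whether methylamino, diethylamino or acetylamino on the same carbon would follow dimethylamino or formylamino. Also open, going by these compounds, is whether the step holds with a butyl chain in place of the methyl group.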